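Swapping 4-nitrophenyl for 2-methoxyphenyl

This account rests on a few compounds, and the source may have more. Where it says the series, first, only, none or still open, it means among the compounds named here.

In a functional assay on HT-29 cells (Homo sapiens) for antiproliferative activity, read by MTT assay, with a stated time of 48 h (a lower number here means a stronger inhibitor of growth, a higher number a weaker inhibitor of growth), compound 1 `S=C(Nc1ccccc1)N1N=C(c2ccccc2)CC1c1ccc2c(c1)OCCO2` gives 6630 nM, and compound 3 `O=[N+]([O-])c1ccc(C2=NN(C(=S)Nc3ccccc3)C(c3ccc4c(c3)OCCO4)C2)cc1` gives 153000 nM, the higher of these two numbers. Compound 2 `CSc1ccc(C2=NN(C(=S)Nc3ccccc3)C(c3ccc4c(c3)OCCO4)C2)cc1` reads > 200000 nM, which is a limit of the assay and not a number. Compound 4 `COc1ccccc1C1=NN(C(=S)Nc2ccccc2)C(c2ccc3c(c2)OCCO3)C1` has 2-methoxyphenyl in place of 4-nitrophenyl on a carbon with a double bond to nitrogen. Two large steps bear on this: adding nitro gave a 23-fold higher number from compound 1 to compound 3 (1.36 log units; beyond the scatter), and adding methylsulfanyl gave an at least 30-fold higher number from compound 1 to compound 2 (1.47 log units; beyond the scatter). Compound 4 lacks the nitro group of compound 3 but still carries a group that compound 1 lacks, so only a partial return towards 6630 nM is expected. The expected step in this assay is moderate, a 5.1-fold lower number from compound 3 to compound 4 (0.71 log units; beyond the scatter). For compound 4 the estimated value is 30000 nM, with an expected range of 4000 nM to 180000 nM.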

Compound 4, concentration for 50% growth inhibition: 30500 nM
Estimate against measurement, compound 4: 1.0-fold (0.01 log units) below, within the range that was stated.
By their numbers in this assay, from the lowest: compound 1; then compound 4; then compound 3. At a limit, above all of these: compound 2.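

In this assay, 2-methoxyphenyl on this carbon with a double bond to nitrogen gives a 5.0-fold lower number from compound 3 to compound 4 (0.70 log units; beyond the scatter), yet it still gives a 4.6-fold higher number from compound 1 to compound 4 (0.66 log units; beyond the scatter). A group on this phenyl ring therefore need not cost as much as the nitro group did, although all three substituted rings shown read higher than the plain phenyl of compound 1. Compound 2 reads at a limit of the assay, not a number, and an at least 6.5-fold lower number from compound 2 to compound 4 (0.81 log units; beyond the scatter) is only a floor.

Going by these compounds, compound 3 and compound 4 differ in both the group and its place on the ring, so the separate contribution of each remains open. A 4-methoxyphenyl or 4-aminophenyl group could help separate them.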